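Replacing iodo with nitro after two assay limits

The source may report more compounds than this note shows. Statements on the series, on what has been measured and on what is new or still open speak of the compounds shown alone.

Compound 1 (`CC(=O)Nc1ccc(-c2nc3ccccc3s2)cc1Br`) and compound 2 (`CC(=O)Nc1ccc(-c2nc3ccccc3s2)cc1I`) share one core and were both tested in a functional assay on MDA-MB-468 cells (Homo sapiens) for antiproliferative activity; on this read-out lower numbers stand for stronger inhibition and higher numbers for weaker inhibition. Compound 1 gives > 100 nM, which is a limit of the assay and not a number. Compound 2 gives > 100 nM, which is also a limit and not a number. This is where compound 2 stands: no exact value is known for it, and the data so far are described by the limit of > 100 nM in this assay, at which 2 of the 2 values shown sit.

Compound 3 (`CC(=O)Nc1ccc(-c2nc3ccccc3s2)cc1[N+](=O)[O-]`) differs from compound 2 by a single change, (nitro in place of iodo on an aromatic carbon). The nitro group sits ortho to an acetamido group and meta to a group of 9 heavy atoms.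

Among the measured compounds shown here, the only measured step is a step that the two limits leave unreadable from compound 1 to compound 2, so it offers no size or direction to carry forward. For the measured compounds named here, no step of known size can therefore be expected in this assay, and another limit is the most likely result. For compound 3 the estimated value is 300 nM, with an expected range of 100 nM to 3000 nM. The expected change is a step that the limit leaves unreadable from compound 2 to compound 3.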

Compound 3, half-maximal inhibitory concentration: > 1000 nM
Compound 3 gave a limit, no number; the forecaster's own chance of this, stated with the estimate: 70%; middle value at least 3.3-fold (0.52 log units) away from the limit.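

Compound 3 gives > 1000 nM, which is a limit of the assay and not a number. Among the compounds shown here, with only limits for compound 1, compound 2 and compound 3, no step among them can be read. The compounds shown leave open how strongly each one inhibits, and whether bromo, iodo or nitro at this position changes activity at all.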